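Hydroxypyrrolidine in Place of Cyclopropylmethylamino at the Tolerance Ceiling

The compounds below may be only part of what the source reports. "The series", "measured", "known", "first", "only" and "open" are said of these compounds alone.

Compound 1, `CNc1cc(Oc2c(OC)cc3cc(C#N)ccc3c2OC)nc(Nc2ccc(C#N)cc2)n1`: 239000 nM
Compound 2, `CCC(C)Nc1cc(Oc2c(OC)cc3cc(C#N)ccc3c2OC)nc(Nc2ccc(C#N)cc2)n1`: > 125000 nM
Compound 3, `COc1cc2cc(C#N)ccc2c(OC)c1Oc1cc(NCC2CC2)nc(Nc2ccc(C#N)cc2)n1`: > 125000 nM

In an ADME assay on MT4 cells (Homo sapiens) for cytotoxicity, read by MTT assay, with a stated time of 5 days (a lower number here means that less compound is tolerated, a higher number that more compound is tolerated), compound 1 gives 239000 nM. For compound 2 the value > 125000 nM is a limit of the assay and not a number. For compound 3 the value > 125000 nM is likewise a limit. Compound 3 thus stands at the ceiling of what was tested, sharing it with one other compound: the limit of > 125000 nM in this assay, at which 2 of the 3 values shown sit. All three steps among the measured compounds touch this region, yet none can be sized: a step that the limit leaves unreadable from compound 1 to compound 2, a step that the limit leaves unreadable from compound 1 to compound 3 and a step that the two limits leave unreadable from compound 2 to compound 3 stay unreadable.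

Compound 4, `COc1cc2cc(C#N)ccc2c(OC)c1Oc1cc(N2CCC(O)C2)nc(Nc2ccc(C#N)cc2)n1`, differs from compound 3 in a single place: 3-hydroxypyrrolidin-1-yl in place of (cyclopropylmethyl)amino on an aromatic carbon. Among the compounds with values here, no measured step bearing on this position shows a readable change in either direction, and compound 3 already sits at the limit. The step that the limit leaves unreadable from compound 3 to compound 4 is therefore expected to be small, with compound 4 most likely reported again as a limit. Compound 4 is estimated at 150000 nM, within 60000 nM to 300000 nM.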

Compound 4, half-maximal cytotoxic concentration: > 125000 nM
Compound 4 gave a limit, no number; the forecaster's own chance of this, stated with the estimate: 60%; the middle value lies beyond the limit too.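

In this assay compound 4 gives > 125000 nM, a limit of the assay and not a number. Its steps from compound 1, compound 2 and compound 3 therefore cannot be read. The compounds shown leave open whether these groups differ at all in how much compound is tolerated.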